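The compounds below may be only part of what the source reports. "The series", "measured", "known", "first", "only" and "open" are said of these compounds alone.

Working notes on the series.

Compound 1 has the structure `COc1ccc(Sc2nc3cc(N)cc(N)c3nc2-c2ccccc2)cc1`. In a functional assay on MOLT-4 cells (Homo sapiens) for inhibition, read by sulforhodamine B assay, with a stated time of 48 h (a lower number here means that less compound is tolerated, a higher number that more compound is tolerated), compound 1 gives only a limit, < 100000 nM, not a number. Compound 2, `Nc1cc(N)c2nc(-c3ccccc3)c(Sc3ccc(Cl)c(Cl)c3)nc2c1`, carries a 3,4-dichlorophenyl in place of the 4-methoxyphenyl on the sulfur. In this assay compound 2 likewise gives only a limit, < 100000 nM. The step from compound 1 to compound 2 is therefore a step that the two limits leave unreadable from compound 1 to compound 2: both ends sit at the same limit and the size of the change cannot be read. For the measured compounds named here, this is the whole of the measured evidence so far; (the limit of < 100000 nM in this assay, at which 2 of the 2 values shown sit), so no step with a readable size is available, and where compound 2 stands among the values shown is known only as a limit.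

Compound 3, `Nc1cc(N)c2nc(-c3ccccc3)c(Oc3ccc(F)cc3)nc2c1`, is not yet measured. It differs from compound 2 by 4-fluorophenoxy in place of (3,4-dichlorophenyl)sulfanyl on an aromatic carbon. Going by the values given here, no measured step bears on this kind of change, and the single measured step gives no size to lean on. The only anchor for this assay is the limit at which compound 2 sits, so the expectation is that compound 3 is at or below that limit.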

Compound 3, concentration lethal to 50% of the cells: < 100000 nM
Compound 3 gave a limit, no number; the forecaster's own chance of this, stated with the estimate: 45%; the middle value does not contradict the limit.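

In this assay compound 3 gives only a limit, not a number, so the steps to it from compound 1 and from compound 2 cannot be read: the limit of < 100000 nM in this assay, at which 3 of the 3 values shown sit.

The compounds shown leave open where compound 1, compound 2 and compound 3 actually lie under that limit, and whether they differ at all.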